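Benzyl in Place of Methoxyalkyl: Expected Microsomal Clearance

A few compounds are considered here, and "the series" means these few. Any claim that something is new, unique, unknown or untested is made for them only; others in the source may bear on it.

Compound 1, `COC(C)(C)[C@@H](O)C(=O)N1N=CC[C@H]1C(=O)NCc1cc(Cl)ccc1-n1cnnn1`: < 12 mL.min-1.g-1
Compound 2, `CC(C)(C)[C@@H](O)C(=O)N1NCC[C@H]1C(=O)NCc1cc(Cl)ccc1-n1cnnn1`: 15 mL.min-1.g-1

In an ADME assay on liver for metabolic stability, with Liver microsome (Homo sapiens) as the target, read by LC-MS, using microsomes (on this read-out lower numbers stand for slow clearance and higher numbers for fast clearance), compound 1 gives < 12 mL.min-1.g-1, which is a limit of the assay and not a number. Compound 2 gives 15 mL.min-1.g-1 in this assay. The two values show no difference beyond the usual scatter. Compound 3, `O=C(NCc1cc(Cl)ccc1-n1cnnn1)[C@@H]1CC=NN1C(=O)[C@H](O)Cc1ccccc1`, awaits measurement; it differs from compound 1 by benzyl in place of 1-methoxy-1-methylethyl on a saturated chain carbon bound to a carbonyl carbon and an oxygen on a saturated carbon. Among the measured compounds shown here, no measured step covers this change. Compound 1 stands at the limit, so only a rise in clearance, or none beyond the scatter, can be read from it; a modest rise is expected, with a step of an at least 2.0-fold higher number from compound 1 to compound 3 (0.31 log units; beyond the scatter). For compound 3 an intrinsic clearance of 25 mL.min-1.g-1 is estimated, ranging from 10 mL.min-1.g-1 to 60 mL.min-1.g-1.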

Compound 3, intrinsic clearance in microsomes: < 12 mL.min-1.g-1
Compound 3: no number, only a limit; the forecaster's own chance of this, stated with the estimate: 20%; middle value at least 2.0-fold (0.31 log units) away from the limit.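

In this assay compound 3 gives < 12 mL.min-1.g-1, a limit and not a number. No step between compound 1 and compound 3 can be read, because both stand at it: the limit of < 12 mL.min-1.g-1 in this assay, at which 2 of the 3 values shown sit.

As far as these compounds go, whether benzyl in place of 1-methoxy-1-methylethyl changes clearance at all stays open.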